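Amide variation on the aryloxyacetyl side chain of the shared core

This account rests on a few compounds, and the source may have more. Where it says the series, first, only, none or still open, it means among the compounds named here.

Measured compounds:
compound 1, `COC(=O)C1=C(C)NC(C)=C(C(=O)OC)C1c1ccc(OCC(=O)N2CCCC(C)C2)c(OC)c1`, 10000 nM
compound 2, `COC(=O)COc1cccc(C2C(C(=O)OC)=C(C)NC(C)=C2C(=O)OC)c1`, 10000 nM
compound 3, `COC(=O)C1=C(C)NC(C)=C(C(=O)OC)C1c1ccc(OCC(=O)n2ccnc2)c(OC)c1`, 10100 nM

In an assay on cells for inhibition of Voltage-gated L-type calcium channel (Rattus norvegicus), read by fluorescence and calcium flux, with stated times of 30 min and 2 min (a higher number here means a weaker inhibitor, a lower number a stronger inhibitor), compound 3 gives 10100 nM, the highest of the three numbers, but its nearest neighbour compound 1 and its furthest neighbour compound 2 both sit within the scatter of it, so no order among the three can be read. Going by the values given here, the one step measured along this side chain, a 1.0-fold higher number from compound 1 to compound 3 (0.00 log units; within the scatter), swaps one amide-type substituent on the carbonyl carbon for another and moves nothing beyond the scatter.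

Compound 4, `COC(=O)C1=C(C)NC(C)=C(C(=O)OC)C1c1ccc(OCC(=O)N2CCCC2)c(OC)c1`, not yet measured, makes a comparable swap at the same carbonyl carbon: pyrrolidin-1-yl in place of 1H-imidazol-1-yl on a carbonyl carbon. Among the compounds with values here, the step from compound 1 to compound 3 is the only measured step that bears on it, and it was flat. An expected step in this assay of about a 1.0-fold lower number from compound 3 to compound 4 (0.00 log units; within the scatter), i.e. none beyond the scatter, follows; in this assay compound 4 is therefore estimated at 10000 nM, with a range from 4000 nM to 25000 nM.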

Compound 4, half-maximal inhibitory concentration: 5600 nM
Beside the measured number, compound 4's estimate is 1.8-fold (0.25 log units) above it; the measured number falls inside the stated range.
By their numbers in this assay, from the lowest: compounds 4, 1, 2 and 3 (each within the scatter of the next).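

In this assay, pyrrolidin-1-yl gives a third amide-type group on this carbonyl carbon, and both new comparisons stay flat (a 1.8-fold lower number from compound 3 to compound 4 (0.26 log units; within the scatter); a 1.8-fold lower number from compound 1 to compound 4 (0.25 log units; within the scatter)). With 3-methylpiperidin-1-yl, 1H-imidazol-1-yl and pyrrolidin-1-yl all within the scatter of one another, exchanging the aromatic five-membered ring for a non-aromatic one of the same heavy-atom count, with hydrogen-bond acceptors going from 2 to 0, produces no readable difference in these three compounds. No data are available to explain this flat result.

As far as these compounds go, whether morpholin-4-yl or an open-chain diethylamino group on this carbonyl carbon would read outside this scatter remains open. Also open, from the compounds shown here alone, is how a carboxylic acid in place of the amide would read on the same side chain.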